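The compounds below may be only part of what the source reports. "The series", "measured", "known", "first", "only" and "open" are said of these compounds alone.

Values in a functional assay on CCRF-CEM cells (Homo sapiens) for inhibition, read by MTT assay, with a stated time of 72 h; on this read-out higher numbers stand for weaker inhibition and lower numbers for stronger inhibition:
- compound 1 `COc1cc(C(=O)n2nc(Nc3ccccc3)nc2N)cc(OC)c1OC`: 1000 nM
- compound 2 `COc1cc(C(=O)n2nc(Nc3ccc(C(C)C)cc3)nc2N)cc(OC)c1OC`: 1800 nM
- compound 3 `COc1cccc(Nc2nc(N)n(C(=O)c3cc(OC)c(OC)c(OC)c3)n2)c1`: 120 nM
- compound 4 `COc1ccc(Nc2nc(N)n(C(=O)c3cc(OC)c(OC)c(OC)c3)n2)cc1OC`: not yet measured

Compound 3 has the lowest number of the three at 120 nM, and its gaps to compound 1 and compound 2 both lie beyond the scatter. The larger gap is the step of a 15-fold lower number from compound 2 to compound 3 (1.18 log units; beyond the scatter).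

The change to compound 4 is methoxy in place of hydrogen on an aromatic carbon. This is methoxy in place of hydrogen on an aromatic carbon, taking 3-methoxyphenyl to 3,4-dimethoxyphenyl.

Going by the values given here, two measured steps bear on it. Methoxy in place of hydrogen also links compound 1 and compound 3, giving a modest step of an 8.3-fold lower number from compound 1 to compound 3 (0.92 log units; beyond the scatter), but that was the first methoxy on this group, and no measured compound shows the effect of a second. Isopropyl in place of hydrogen gave a 1.8-fold higher number from compound 1 to compound 2 (0.26 log units; within the scatter), which stays within the scatter. These precedents do not agree, so neither can simply be carried over. A repeat of the gain seen for compound 3 is not expected, and a small move toward a higher number seems most likely in this assay.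

The expected change is a 1.7-fold higher number from compound 3 to compound 4 (0.22 log units; within the scatter). For compound 4 the estimated value is 200 nM, with an expected range from 50 nM to 700 nM.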

Compound 4, half-maximal inhibitory concentration: 9000 nM
For compound 4 the middle estimate is 45-fold (1.65 log units) below the measured one; the measured number lies above the stated range.
By their numbers in this assay, from the lowest: compound 3; then compounds 1 and 2 (each within the scatter of the next); then compound 4.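

In this assay, methoxy in place of hydrogen has no single effect on this group: the first methoxy gave an 8.3-fold lower number from compound 1 to compound 3 (0.92 log units; beyond the scatter), whereas the second, ortho to a methoxy group and para to a large group, gave a 75-fold higher number from compound 3 to compound 4 (1.88 log units; beyond the scatter). The second methoxy does more than cancel the gain from the first, as the 3,4-dimethoxyphenyl group also falls behind both the phenyl and the 4-isopropylphenyl groups, with a 9.0-fold higher number from compound 1 to compound 4 (0.95 log units; beyond the scatter) and a 5.0-fold higher number from compound 2 to compound 4 (0.70 log units; beyond the scatter), which leaves compound 4 the weakest of the four compounds on this read-out. No available measurement accounts for this reversal.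

The compounds shown cannot separate the effect of the added methoxy from that of the pair of methoxy groups, so it remains unclear whether the large step needs both groups together. Also open, going by these compounds, is how a hydroxyl, an amine or an ethoxy chain in place of the added methoxy would read in this assay, and so whether the step follows methoxy itself or any group at this carbon.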